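A few compounds are considered here, and "the series" means these few. Any claim that something is new, unique, unknown or untested is made for them only; others in the source may bear on it.

In a functional assay on a cell-free system (Platelet, plasma, Homo sapiens) for inhibition (a lower number here means a stronger inhibitor, a higher number a weaker inhibitor), compound 1 `Cc1ccc(N(CCN2CCC(OCC(=O)O)CC2)C(=O)c2ccc(Cl)cc2)cc1`, with 4-chlorophenyl on a carbonyl carbon, gives 690 nM, while compound 2 `COc1cccc(C(=O)N(CCN2CCC(OCC(=O)O)CC2)c2ccc(C)cc2)c1`, with 3-methoxyphenyl there, gives 32 nM, the lower of the two numbers. Compound 3 `Cc1ccc(N(CCN2CCC(OCC(=O)O)CC2)C(=O)c2cccc(C(F)(F)F)c2)cc1` has trifluoromethyl in place of methoxy on an aromatic carbon, giving a 3-(trifluoromethyl)phenyl group. Within the data shown here, only one measured step bears on this change: a 22-fold lower number from compound 1 to compound 2 (1.33 log units; beyond the scatter), which is large and beyond the scatter. Among the measured compounds shown here, that step exchanged the whole group on the carbonyl carbon, and no measured pair compares methoxy with trifluoromethyl directly. Compound 3 keeps the substituent in the same place as compound 2, so a partial return towards the higher number is expected, not a change as large as the measured step. The expected step is a 3.1-fold higher number from compound 2 to compound 3 (0.49 log units; beyond the scatter). For compound 3 the estimated value is 100 nM, with an expected range from 25 nM to 400 nM.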

Compound 3, half-maximal inhibitory concentration: 20000 nM
Compound 3: middle estimate off by 200-fold (2.30 log units), on the low side; the whole stated range lies below it.
By their numbers in this assay, from the lowest: compound 2; then compound 1; then compound 3.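

In this assay, exchanging methoxy for trifluoromethyl on this aromatic carbon gives a 630-fold higher number from compound 2 to compound 3 (2.80 log units; beyond the scatter), so this single substituent change outweighs the whole-group exchange seen earlier, a 22-fold lower number from compound 1 to compound 2 (1.33 log units; beyond the scatter). The 3-(trifluoromethyl)phenyl group also falls behind 4-chlorophenyl, with a 29-fold higher number from compound 1 to compound 3 (1.46 log units; beyond the scatter), which shows that keeping a substituent in the place held by methoxy does not by itself preserve the low number of compound 2. Nothing available explains why these two groups differ so sharply at this position.

The compounds shown leave open whether the low number is specific to methoxy or would also be reached with an ethoxy, a hydroxyl or an amine in that place. They also do not show how methoxy would behave elsewhere on the same ring.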